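Four chlorinated purine-like cores and a cytotoxicity read-out

The source may hold more compounds than are shown below. What is called first, only, known or untested is meant among the compounds shown, and "the series" means these compounds.

Of the compounds shown here, three have been measured in a functional assay on K562 cells (Homo sapiens) for cytotoxicity, read by sulforhodamine B assay, with a stated time of 48 h; a lower number here means that less compound is tolerated, a higher number that more compound is tolerated. Compound 1 `ClCc1ccc(Cn2cnc3c(Cl)ncnc32)cc1` carries one chloro group on its six-membered ring. Compound 2 `ClCc1ccc(Cn2cnc3nc(Cl)nc(Cl)c32)cc1` and compound 3 `ClCc1ccc(Cn2cnc3c(Cl)nc(Cl)nc32)cc1` each carry two chloro groups; the difference between the two cores is not broken down here. In this assay compound 1 gives > 100000 nM, which is a limit of the assay and not a number. Compound 2 gives > 100000 nM, also a limit. Compound 3 gives > 100000 nM, again a limit. All three values therefore share (the limit of > 100000 nM in this assay, at which 3 of the 3 values shown sit).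

Compound 3 and compound 1 differ in one place, (hydrogen in place of chloro on an aromatic carbon). The step this change made, a step that the two limits leave unreadable from compound 3 to compound 1, cannot be read, since both ends of it are limits.

Compound 4 `ClCc1ccc(Cn2cnc3ncnc(Cl)c32)cc1` has not yet been measured. It differs from compound 2 by hydrogen in place of chloro on an aromatic carbon, the same change that turns compound 3 into compound 1; the surroundings of the place are described in the same words for both pairs, so this is the same change made a second time.

The step from compound 2 to compound 4 is expected to be about a step that the limit leaves unreadable from compound 2 to compound 4 in this assay. That expectation rests on the unreadable step that the two limits leave unreadable from compound 3 to compound 1 and on compound 2 sitting at a limit. Compound 4 is therefore estimated to come out at about 200000 nM, most likely reported once more as a limit rather than a number, somewhere between 100000 nM and 1000000 nM.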

Compound 4, concentration lethal to 50% of the cells: > 100000 nM
Compound 4 ended at the assay's limit; the forecaster's own chance of this, stated with the estimate: 85%; the middle value is on the limit's open side.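

In this assay compound 4 gives > 100000 nM, which is a limit of the assay and not a number. Compound 2 also sits at a limit, so no new step can be read between compound 2 and compound 4. All four compounds end at the same place: the limit of > 100000 nM in this assay, at which 4 of the 4 values shown sit.

The compounds shown leave open whether hydrogen in place of chloro changes the cytotoxicity at all, and how the four compounds rank against one another.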